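The compounds below may be only part of what the source reports. "The series", "measured", "known", "first", "only" and "open" are said of these compounds alone.

Measured so far:
compound 1 `CSCSCC1C2CCC(O2)C1C/C=C\CCCC(=O)O`, 700 nM
compound 2 `O=C(O)CCC/C=C\CC1C2CCC(O2)C1CSCCc1ccccc1`, 5500 nM
compound 3 `CCCCSCC1C2CCC(O2)C1C/C=C\CCCC(=O)O`, 1000 nM

In a functional assay on a cell-free system (plasma) for inhibition of thromboxane A2 receptor (Homo sapiens) (a higher number here means a weaker inhibitor, a lower number a stronger inhibitor), compound 3 gives the second highest of the three numbers; compound 1 sits within the scatter of it, while compound 2 gives a number beyond the scatter above it. Compound 4 `CCC/C=C(\C)CSCC1C2CCC(O2)C1C/C=C\CCCC(=O)O` differs from compound 3 by a group of 6 heavy atoms (6 carbon; no ring) in place of a group of 3 heavy atoms (3 carbon; no ring), on a saturated chain carbon bound to a sulfur. For the measured compounds named here, two steps bear on it: a 1.4-fold higher number from compound 1 to compound 3 (0.15 log units; within the scatter), and a 5.5-fold lower number from compound 2 to compound 3 (0.74 log units; beyond the scatter), the latter showing that a larger, ring-bearing group on this chain carbon costs potency. Compound 4 carries a longer chain but no ring, so a small step upward in this assay is expected, a 1.5-fold higher number from compound 3 to compound 4 (0.18 log units; within the scatter). For compound 4 the estimate is 1500 nM, within 500 nM to 4500 nM.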

Compound 4, half-maximal inhibitory concentration: 1100 nM
Beside the measured number, compound 4's estimate is 1.4-fold (0.13 log units) above it, and the stated range covers the measured number.
By their numbers in this assay, from the lowest: compounds 1, 3 and 4 (each within the scatter of the next); then compound 2.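

In this assay, the ringless group of 6 heavy atoms with its double bond stays within the scatter of propyl, a 1.1-fold higher number from compound 3 to compound 4 (0.04 log units; within the scatter), and of methylsulfanyl, a 1.6-fold higher number from compound 1 to compound 4 (0.20 log units; within the scatter), so a longer chain on this saturated chain carbon bound to a sulfur brings no measurable loss. The ring-bearing group of compound 2 remains the outlier, a 5.0-fold lower number from compound 2 to compound 4 (0.70 log units; beyond the scatter), which shows that group size alone does not track the higher number. No evidence is available to explain this.

Whether the double bond matters remains open, since a fully saturated chain of the same length is not among these compounds. The effect of an amine or a hydroxyl on this chain is also unknown.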